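Removing a Methoxy Group: What to Expect for Compound 4

The source may hold more compounds than are shown below. What is called first, only, known or untested is meant among the compounds shown, and "the series" means these compounds.

In an ADME assay on microsomes from liver (Mus musculus) for metabolic stability, read by LC-MS, using NADPH, with a stated time of 60 min, tested at 1 uM (a lower number here means that the compound disappears faster, a higher number that the compound lasts longer), compound 1 `Cc1cc(C)c(O)c(-n2c(N)nc3ccccc32)c1` gives 0.0667 h, compound 2 `Cc1cc(O)c(-n2c(N)nc3ccccc32)cc1C` gives 0.383 h, and compound 3 `COc1ccc(-n2c(N)nc3ccccc32)c(O)c1` gives 0.1 h. Compound 3 stands second highest of these three numbers: its value lies within the usual scatter of that of compound 1, while compound 2 sits clearly higher, beyond the scatter. Compound 4 `Nc1nc2ccccc2n1-c1ccccc1O` is the next to be measured. It differs from compound 3 in one place: hydrogen in place of methoxy on an aromatic carbon. Among the measured compounds shown here, no two measured compounds differ by this kind of change, so its effect in this assay is not known from the data at hand. For compound 4 a step of a 1.5-fold higher number from compound 3 to compound 4 (0.18 log units; within the scatter) is expected, small and not beyond the scatter. Compound 4 is estimated to give 0.15 h, with a likely range from 0.06 h to 0.4 h.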

Compound 4, half-life in the Mus musculus assay: 1.3 h
Compound 4: middle estimate off by 8.7-fold (0.94 log units), on the low side, outside the stated range (above it).
By their numbers in the Mus musculus assay, from the lowest: compounds 1 and 3 (each within the scatter of the next); then compound 2; then compound 4.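

Removing the methoxy group from this place, para to a large group and meta to a hydroxy group, brings in the Mus musculus assay a 13-fold higher number from compound 3 to compound 4 (1.11 log units; beyond the scatter), so a single change here can shift the half-life strongly. In a physicochemical assay for solubility, read by nephelometry, measured as kinetic solubility, with a stated time of 30 min, at pH 7.4 (a higher number here means a more soluble compound, a lower number a less soluble compound), compound 3 gives 50 ug/mL. In the physicochemical assay compound 4 gives > 100 ug/mL, which is a limit of the assay and not a number: the limit of > 100 ug/mL in the physicochemical assay, at which 1 of the 2 values shown sits.

This single pair cannot show whether the size of the group or something else about methoxy matters. As far as these compounds go, how a fluorine atom, an amine or a longer chain at this place would behave remains open.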